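This account rests on a few compounds, and the source may have more. Where it says the series, first, only, none or still open, it means among the compounds named here.

Measured in a functional assay on MGC-803 cells (Homo sapiens) for inhibition, read by MTT assay, with a stated time of 72 h; a higher number here means a weaker inhibitor, a lower number a stronger inhibitor:

- compound 1 `Cc1ccc(Cn2cc(CSC(=S)N3CCN(C(=O)OC(C)(C)C)CC3)nn2)cc1`: 3490 nM
- compound 2 `CC(C)(C)OC(=O)N1CCN(C(=S)SCc2cn(Cc3ccc(Cl)c(Cl)c3)nn2)CC1`: 33700 nM
- compound 3 `COc1ccc(Cn2cc(CSC(=S)N3CCN(C(=O)OC(C)(C)C)CC3)nn2)cc1`: 22800 nM

Compound 3 stands second highest of the three numbers in this assay. Its gap to compound 1 is real: a 6.5-fold higher number from compound 1 to compound 3 (0.82 log units; beyond the scatter). Its gap to compound 2 is not: a 1.5-fold lower number from compound 2 to compound 3 (0.17 log units; within the scatter).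

Within the data shown here, compound 4 `CC(C)(C)OC(=O)N1CCN(C(=S)SCc2cn(Cc3ccc(Cl)cc3)nn2)CC1` differs from compound 3 by chloro in place of methoxy on an aromatic carbon, a change that none of the measured steps covers directly. Among the measured compounds shown here, two steps bear on it indirectly. Moving from methyl to methoxy at that same aromatic carbon raised the number, a 6.5-fold higher number from compound 1 to compound 3 (0.82 log units; beyond the scatter). Moving from 4-methylphenyl to 3,4-dichlorophenyl raised it somewhat more, a 9.7-fold higher number from compound 1 to compound 2 (0.98 log units; beyond the scatter), yet compound 2 and compound 3 sit within the scatter of each other. A single chloro in place of methoxy is therefore expected to leave the number near that of compound 3, with no step beyond the scatter in this assay.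

Compound 4 is estimated at 20000 nM, range 7000 nM to 60000 nM, which as a step from compound 3 is a 1.1-fold lower number from compound 3 to compound 4 (0.06 log units; within the scatter).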

Compound 4, half-maximal inhibitory concentration: 9790 nM
Compound 4: the middle estimate sits 2.0-fold (0.31 log units) above what was measured, within the range that was stated.
By their numbers in this assay, from the lowest: compound 1; then compound 4; then compounds 3 and 2 (each within the scatter of the next).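

In this assay, the aromatic carbon para to a large group now separates chloro from methoxy (a 2.3-fold lower number from compound 3 to compound 4 (0.37 log units; beyond the scatter)), so a swap of one group at this carbon moves the number beyond the scatter. Losing the extra chloro of the 3,4-dichlorophenyl group also counts (a 3.4-fold lower number from compound 2 to compound 4 (0.54 log units; beyond the scatter)), so the 4-chlorophenyl group reads differently from the 3,4-dichlorophenyl group, although the latter and the 4-methoxyphenyl group lie within the scatter of each other. Methyl still gives a lower number than chloro (a 2.8-fold higher number from compound 1 to compound 4 (0.45 log units; beyond the scatter)), which places the three groups at this carbon in the order methyl, chloro, methoxy, from the lowest number up.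

Nothing on hand accounts for this order. From the compounds shown here alone, whether it extends to hydrogen, an amine or a carboxylic acid at this carbon stays open, as does the effect of a chloro elsewhere on the ring without the one at this carbon.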